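The source may hold more compounds than are shown below. What is called first, only, known or untested is meant among the compounds shown, and "the series" means these compounds.

Measured so far:
compound 1 `CNC(=S)N/N=C1\C(=O)Nc2ccccc21`: > 25000 nM
compound 2 `CN(C)C(=S)N/N=C1/C(=O)Nc2ccccc21`: > 25000 nM

Both compounds were tested in an ADME assay on RD cells (Homo sapiens) for cytotoxicity; a higher number here means that more compound is tolerated, a lower number that less compound is tolerated. In this assay compound 1 gives > 25000 nM, which is a limit of the assay and not a number. In this assay compound 2 gives > 25000 nM, again a limit. Among the compounds with values here, compound 1 thus stands at the limit of > 25000 nM in this assay, at which 2 of the 2 values shown sit, and no measured step between the two compounds exists. Compound 3 `CCCNC(=S)N/N=C1\C(=O)Nc2ccccc21` is not yet measured. It differs from compound 1 by ethyl in place of hydrogen on a saturated chain carbon bound to an amide-type nitrogen. For this change only a step that the limit leaves unreadable from compound 1 to compound 3 is expected, that is none beyond the scatter. Compound 3 is therefore estimated at 30000 nM, within 12000 nM to 80000 nM.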

Compound 3, half-maximal cytotoxic concentration: > 25000 nM
Compound 3 gave a limit, no number; the forecaster's own chance of this, stated with the estimate: 80%; the middle value lies beyond the limit too.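

Compound 1 and compound 3 each give only a limit in this assay, so no step between them can be read: the limit of > 25000 nM in this assay, at which 3 of the 3 values shown sit.

The compounds shown leave open at what concentration any of them harms the cells, and whether ethyl in place of hydrogen changes that at all.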